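The compounds below may be only part of what the source reports. "The series", "measured", "known", "first", "only" and "open" are said of these compounds alone.

In a functional assay on HL-60 cells (Homo sapiens) for antiproliferative activity, read by MTT assay, with a stated time of 72 h (on this read-out lower numbers stand for stronger inhibition and higher numbers for weaker inhibition), compound 1 `CCn1cc(C(=O)O)c(=O)c2cc(F)c(N3CCN(C(=N)NS(=O)(=O)c4cccc(Cl)c4)CC3)cc21` gives 43 nM and so stands level with the other two measured compounds. Compound 2 `N=C(NS(=O)(=O)c1cccc(Cl)c1)N1CCN(c2cc3c(cc2F)c(=O)c(C(=O)O)cn3C2CC2)CC1` gives 43 nM and compound 3 `N=C(NS(=O)(=O)c1ccc(Cl)cc1)N1CCN(c2cc3c(cc2F)c(=O)c(C(=O)O)cn3C2CC2)CC1` gives 43 nM as well, so none of the three stands apart on these numbers.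

Compound 4 `CCn1cc(C(=O)O)c(=O)c2cc(F)c(N3CCN(C(=N)NS(=O)(=O)c4ccccc4C(F)(F)F)CC3)cc21` has not yet been measured. It keeps the rest of compound 1 but carries 2-(trifluoromethyl)phenyl in place of 3-chlorophenyl on a sulfonyl sulfur.

Two measured steps can guide an expectation. The first, no change at the digits printed from compound 1 to compound 2 (within the scatter) with cyclopropyl in place of ethyl on an aromatic nitrogen, lies in a different place and says little about this change. The closer evidence is no change at the digits printed from compound 2 to compound 3 (within the scatter) with 4-chlorophenyl in place of 3-chlorophenyl on a sulfonyl sulfur, and on this evidence no step beyond the scatter is expected for compound 4 in this assay in either direction.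

That evidence is thin, since no measured compound carries a trifluoromethyl group, and the expected range is kept wide for that reason. The expected outcome is a 1.2-fold higher number from compound 1 to compound 4 (0.07 log units; within the scatter) on this reasoning. Compound 4 is estimated at 50 nM with an expected range from 20 nM to 130 nM when it is measured.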

Compound 4, half-maximal inhibitory concentration: 43 nM
Compound 4: middle estimate off by 1.2-fold (0.07 log units), on the high side; the range from low to high includes it.
By their numbers in this assay, from the lowest: compounds 1, 2, 3 and 4 (each within the scatter of the next).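

In this assay the exchange of 3-chlorophenyl for 2-(trifluoromethyl)phenyl on a sulfonyl sulfur gives no change at the digits printed from compound 1 to compound 4 (within the scatter) and this is a larger change than the earlier shift from 3-chlorophenyl to 4-chlorophenyl, which kept the chlorine. Here the chlorine leaves, three fluorines enter, and the group grows in heavy atoms, yet the printed number stays the same, so this position accepts more than a chlorophenyl group without any visible change in this read-out. No measurement of any property of these groups accompanies the result, so the data offer no explanation for it.

Every group shown on the sulfonyl sulfur is a substituted phenyl ring, so it remains open whether the number would also hold with a phenyl ring carrying an amine or a carboxylic acid, or with a plain butyl chain in place of the ring. As far as these compounds go, it is equally open whether the 2-(trifluoromethyl)phenyl group would give the same result on the cyclopropyl version of the core.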